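A Methylpiperazine Added to a Kinase Binder

A few compounds are considered here, and "the series" means these few. Any claim that something is new, unique, unknown or untested is made for them only; others in the source may bear on it.

Compound 1 `Nc1c2c(=O)[nH]c(-c3ccccc3)cc2nn1-c1ccccc1` was tested in an assay on isolated protein for inhibition of RAC-beta serine/threonine-protein kinase (Homo sapiens), read by mobility shift assay, tested at 30 uM (a lower number here means less inhibition, a higher number more inhibition at the concentration tested (going by the name of the read-out)), and compound 1 gave -1%. Among the measured compounds shown here, its one measured neighbour, compound 2 `Nc1c2c(=O)[nH]c(-c3ccccn3)cc2nn1-c1ccccc1`, differs only by pyridin-2-yl in place of phenyl on an aromatic carbon, and in this assay compound 2 gave 8%. The step between them, a number 9 percentage points higher from compound 1 to compound 2 (within the scatter), is within the scatter. For the measured compounds named here, compound 1 therefore stands as the lowest of the two numbers, with compound 2 as its only comparison and within the scatter of it.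

Compound 3 `CN1CCN(c2ccc(-c3cc4nn(-c5ccccc5)c(N)c4c(=O)[nH]3)cc2)CC1` departs from compound 1 by 4-methylpiperazin-1-yl in place of hydrogen on an aromatic carbon. Going by the values given here, no measured step touches that aromatic carbon, and the only step recorded, a number 9 percentage points higher from compound 1 to compound 2 (within the scatter), concerns a different ring and stayed within the scatter, so it gives no direct precedent for an addition of this kind. With both measured compounds showing almost no inhibition, compound 3 is expected to move by about a number 7 percentage points higher from compound 1 to compound 3 (within the scatter), a shift not beyond the scatter. Compound 3 is thus estimated at 6%, within a range from -10% to 28%.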

Compound 3, a percentage reported as inhibition, at one concentration (the size of the read-out at that concentration, not a potency): 10%
Beside the measured number, compound 3's estimate is 4 percentage points below it; the range from low to high includes it.
By their numbers in this assay, from the lowest: compounds 1, 2 and 3 (each within the scatter of the next, the first and the last beyond it).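

At the aromatic carbon para to a large group, on the six-membered aromatic ring of carbon only, compound 1 takes on 4-methylpiperazin-1-yl, with its 7 heavy atoms, and this assay records a number 11 percentage points higher from compound 1 to compound 3 (beyond the scatter) as a modest rise. Among the compounds shown here, this is the first step that is printed as beyond the scatter, whereas the change of ring in a number 9 percentage points higher from compound 1 to compound 2 (within the scatter) stayed inside it, so this carbon is the only place so far where a change registers, although compound 3 at 10% still shows only a small read-out at a single concentration and gives no potency. No evidence on hand accounts for the step.

The compounds shown leave open whether the whole 4-methylpiperazin-1-yl group matters or only part of it, a question that a morpholin-4-yl group, an unsubstituted piperazin-1-yl group or a simple dimethylamino group at the same carbon would address. Also open, from the compounds shown here alone, is whether a longer chain ending in an amine would carry the number further at this carbon, and whether 4-methylpiperazin-1-yl would act alike on the pyridin-2-yl ring of compound 2.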